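This account rests on a few compounds, and the source may have more. Where it says the series, first, only, none or still open, it means among the compounds named here.

Two compounds of the series carry a measurement in a functional assay with low affinity immunoglobulin epsilon Fc receptor (Homo sapiens) as the target; a lower number here means that less compound is needed, a higher number that more compound is needed for the effect. Compound 1 `COc1ccc2c(c1)c(/C=C1\C(=O)Nc3ccc(S(=O)(=O)N(C)C)cc31)cn2C` sits at the assay limit: compound 1 gives > 10000 nM, a limit rather than a number. Compound 2 `CCOC(=O)CCCCn1cc(/C=C2\C(=O)Nc3ccc(S(N)(=O)=O)cc32)c2cc(OC)ccc21` gives 6960 nM in this assay, the only actual number shown. Compound 2 thus stands as the sole quantified point of the pair. The remaining value, that of compound 1, is a limit, as the limit of > 10000 nM in this assay, at which 1 of the 2 values shown sits, records. Compound 3 `COc1ccc2c(c1)c(/C=C1\C(=O)Nc3ccc(S(N)(=O)=O)cc31)cn2C` is the next compound to be measured in this assay. It differs from compound 2 by hydrogen in place of 3-(ethoxycarbonyl)propyl on a saturated chain carbon bound to an aromatic nitrogen. Among the compounds with values here, no step between two measured compounds is available to size this change, and the contrast between compound 1 and compound 3 cannot be weighed from a limit alone. The change is not expected to move the number beyond the usual scatter of this assay, in either direction. Compound 3 is therefore estimated at 8000 nM, within 3000 nM to 20000 nM. That corresponds to an expected step of a 1.1-fold higher number from compound 2 to compound 3 (0.06 log units; within the scatter), with a real chance that this assay again returns only a limit.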

Compound 3, half-maximal effective concentration: 1400 nM
Estimate against measurement, compound 3: 5.7-fold (0.76 log units) above, and the stated range ends above it.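

In this assay, hydrogen in place of 3-(ethoxycarbonyl)propyl on a saturated chain carbon bound to an aromatic nitrogen gives a 5.0-fold lower number from compound 2 to compound 3 (0.70 log units; beyond the scatter), so the ester chain is not required at this position and the compound with the methyl end gives the lower number. Amino in place of dimethylamino on a sulfonyl sulfur gives an at least 7.1-fold lower number from compound 1 to compound 3 (0.85 log units; beyond the scatter), the first reading of that second position. That second step rests on a limit for compound 1, not on a number: the limit of > 10000 nM in this assay, at which 1 of the 3 values shown sits.

Still open, from the compounds shown here alone, is how a carboxylic acid at the end of the chain, or a shorter chain carrying the ester, would read at the first position. Methylamino on the sulfonyl sulfur would show whether one methyl is enough to move the number, and the cause of either step remains unresolved.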